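Swapping a Branched Alkenyl Chain for a Straight Butyl

The source may hold more compounds than are shown below. What is called first, only, known or untested is meant among the compounds shown, and "the series" means these compounds.

Compound 1 `COC1Cc2sccc2C2(CCN(CCCCc3ccccc3)CC2)O1` gives 7.7 nM in an assay on membranes from brain for displacement of a labelled ligand from Sigma non-opioid intracellular receptor 1 (Cavia porcellus); on this read-out higher numbers stand for weaker inhibition and lower numbers for stronger inhibition.
Compound 2 `COC1Cc2sccc2C2(CCN(Cc3ccc(F)cc3)CC2)O1` gives 0.62 nM in this assay.
Compound 3 `COC1Cc2sccc2C2(CCN(CC=C(C)C)CC2)O1` gives 1 nM in this assay.

Compound 3 has the second highest of the three numbers. Its nearest neighbour is compound 2: the step of a 1.6-fold higher number from compound 2 to compound 3 (0.21 log units; within the scatter) is within the scatter, so these two cannot be told apart. Compound 1 is furthest away, with a clearly higher number than compound 3.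

Compound 4 `CCCCCN1CCC2(CC1)OC(OC)Cc1sccc12` differs from compound 3 by butyl in place of 2-methylprop-1-en-1-yl on a saturated chain carbon bound to an amine nitrogen in a ring. Within the data shown here, the only measured step at this place, a 1.6-fold higher number from compound 2 to compound 3 (0.21 log units; within the scatter), was within the scatter, and no measured step removes a double bond from this chain. A small change, if any, is therefore expected. Compound 4 is estimated to give 1.8 nM, with a range from 0.6 nM to 6 nM. That estimate means an expected 1.8-fold higher number from compound 3 to compound 4 (0.26 log units; within the scatter).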

Compound 4, inhibition constant: 1.6 nM
Compound 4: middle estimate off by 1.1-fold (0.05 log units), on the high side, and the stated range covers the measured number.
By their numbers in this assay, from the lowest: compounds 2, 3 and 4 (each within the scatter of the next, the first and the last beyond it); then compound 1.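

In this assay the double bond can leave this chain without a readable change, with a 1.6-fold higher number from compound 3 to compound 4 (0.20 log units; within the scatter) as the step. An aromatic ring on the chain does not push the number one way: butyl in place of 4-fluorophenyl brings a 2.6-fold higher number from compound 2 to compound 4 (0.41 log units; beyond the scatter) as a modest rise, whereas methyl in place of phenyl at the chain end brings a 4.8-fold lower number from compound 1 to compound 4 (0.68 log units; beyond the scatter) as a modest fall.

From the compounds shown here alone, how a longer straight chain, or an amine at the chain end, would read remains open. Nothing measured here explains these steps.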